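The compounds below may be only part of what the source reports. "The series", "measured", "known", "first", "only" and "open" are said of these compounds alone.

- Compound 1 (`CC(C)=CC[C@@H](OC(=O)CCO)C1=CC(=O)c2c(O)ccc(O)c2C1=O`): 67600 nM
- Compound 2 (`CC(C)=CC[C@@H](OCCO)C1=CC(=O)c2c(O)ccc(O)c2C1=O`): 18600 nM

In a functional assay on HeLa cells (Homo sapiens) for cytotoxicity, read by MTT assay (a higher number here means a weaker inhibitor, a lower number a stronger inhibitor), compound 2 holds the lower of the two numbers. Compound 3 (`CC(C)=CC[C@@H](OC(=O)C1CCCCO1)C1=CC(=O)c2c(O)ccc(O)c2C1=O`) is not yet measured. It differs from compound 2 as follows: (oxan-2-yl)carbonyl in place of 2-hydroxyethyl on an oxygen on a saturated carbon; that is, (oxan-2-yl)carbonyl in place of 2-hydroxyethyl on an oxygen on a saturated carbon. Among the compounds with values here, the one measured step that bears on this is a 3.6-fold lower number from compound 1 to compound 2 (0.56 log units; beyond the scatter), where 2-hydroxyethyl replaced (2-hydroxyethyl)carbonyl. Compound 3 again carries a carbonyl on that oxygen, so a modest move to a higher number is expected, an estimated 2.4-fold higher number from compound 2 to compound 3 (0.38 log units; beyond the scatter) in this assay. Compound 3 is expected near 45000 nM (estimated range 15000 nM to 130000 nM).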

Compound 3, half-maximal inhibitory concentration: > 100000 nM
Compound 3: only a limit was reported; the forecaster's own chance of this, stated with the estimate: 5%; middle value at least 2.2-fold (0.34 log units) away from the limit.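

In this assay compound 3 gives only a limit, > 100000 nM. Putting (oxan-2-yl)carbonyl in place of 2-hydroxyethyl on this oxygen gives an at least 5.3-fold higher number from compound 2 to compound 3 (0.73 log units; beyond the scatter), so a second carbonyl-bearing group, after the (2-hydroxyethyl)carbonyl of compound 1, also sits on the higher side of compound 2. Exchanging 2-hydroxyethyl for oxan-2-yl on the carbonyl carbon gives an at least 1.4-fold higher number from compound 1 to compound 3 (0.17 log units; that floor lies within the scatter), a floor that sets no order between these two.

As far as these compounds go, the true value of compound 3 remains open. So does how an amine or a carboxylic acid at the end of the 2-hydroxyethyl chain would read.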